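The source may report more compounds than this note shows. Statements on the series, on what has been measured and on what is new or still open speak of the compounds shown alone.

Working notes on the series. Compound 1 `COc1cc2c(cc1N1C[C@@H](C)N(C)[C@@H](C)C1)N(C(=O)c1ccc(-c3cccc(C)n3)c3ccccc13)CC2` and compound 2 `COc1cc2c(cc1N1C[C@@H](C)N[C@@H](C)C1)N(C(=O)c1ccc(-c3cccc(C)n3)c3ccccc13)CC2` share one core and differ only at the ring amine nitrogen. Among the measured compounds shown here, in an in vitro ADME assay on microsomes from liver (Homo sapiens) for metabolic stability (on this read-out lower numbers stand for slow clearance and higher numbers for fast clearance), compound 1 gives 34 mL.min-1.g-1, and in the same assay compound 2 gives 14 mL.min-1.g-1; the single step between them, a 2.4-fold lower number from compound 1 to compound 2 (0.39 log units; beyond the scatter), is the only step measured so far. Compound 2 therefore stands at the lower of the two numbers. The unmeasured compound 3 `CCN1[C@H](C)CN(c2cc3c(cc2OC)CCN3C(=O)c2ccc(-c3cccc(C)n3)c3ccccc23)C[C@@H]1C` returns a substituent to that nitrogen: ethyl in place of hydrogen on an amine nitrogen in a ring. For the measured compounds named here, the one measured step bearing on this change ran in the opposite sense, hydrogen replacing methyl and lowering the number. Reversing the direction with a larger alkyl group, the expectation for compound 3 is a rise of roughly that order, a 2.9-fold higher number from compound 2 to compound 3 (0.46 log units; beyond the scatter), with no measured ethyl analogue to sharpen it. Compound 3 is thus estimated at 40 mL.min-1.g-1 in this assay, within the range 18 mL.min-1.g-1 to 90 mL.min-1.g-1.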

Compound 3, intrinsic clearance in microsomes: 47 mL.min-1.g-1
For compound 3 the middle estimate is 1.2-fold (0.07 log units) below the measured one; low and high end bracket the measured number.
By their numbers in this assay, from the lowest: compound 2; then compounds 1 and 3 (each within the scatter of the next).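

Ethyl in place of hydrogen on the amine nitrogen in the ring gives, in this assay, a 3.4-fold higher number from compound 2 to compound 3 (0.53 log units; beyond the scatter), so the low number of compound 2 now stands against two alkylated compounds rather than one. The step from methyl to ethyl on this nitrogen does not separate the two groups: a 1.4-fold higher number from compound 1 to compound 3 (0.14 log units; within the scatter), so among these three compounds the difference lies between hydrogen and an alkyl group, and chain length adds nothing that can be read beyond the scatter. Nothing at hand accounts for this difference.

Going by these compounds, it remains open whether a longer chain, a cyclopropyl group or an acetyl group on this nitrogen would stay level with compound 1 and compound 3. Also open, on these data alone, is whether the result holds without the two ring methyl groups.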